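Naphthalene for ethylphenyl on the benzyl-bearing core

The compounds below may be only part of what the source reports. "The series", "measured", "known", "first", "only" and "open" are said of these compounds alone.

Measured compounds:
compound 1 `c1ccc2c(-c3cn4ccnc4c(-c4ccc5ncn(C6CCCCC6)c5c4)n3)cccc2c1` — 3.62%
compound 2 `c1cn2cc(-c3ccsc3)nc(-c3ccc4ncn(C5CCCCC5)c4c3)c2n1` — 5.56%
compound 3 `CCc1ccc(-c2cn3ccnc3c(-c3ccc4ncn(Cc5ccccc5)c4c3)n2)cc1` — 21.8%

In a functional assay on Hs-578T cells (Homo sapiens) for inhibition, read by sulforhodamine B assay, with a stated time of 48 h, tested at 10 uM (on this read-out lower numbers stand for less inhibition and higher numbers for more inhibition at the one concentration tested (going by the name of the read-out)), compound 3 gives the highest number of the three, and its gaps to compound 2 and to compound 1 both lie beyond the scatter. Compounds 1 and 2 sit close together; the step of a number 1.9 percentage points higher from compound 1 to compound 2 (within the scatter) is within the scatter.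

Compound 4 `c1ccc(Cn2cnc3ccc(-c4nc(-c5cccc6ccccc56)cn5ccnc45)cc32)cc1` is not yet measured. It differs from compound 3 by naphthalen-1-yl in place of 4-ethylphenyl on an aromatic carbon. Among the compounds with values here, none of the measured steps covers this exchange directly: the one measured step replaces naphthalen-1-yl with thiophen-3-yl, on a core that carries cyclohexyl rather than benzyl, and it changed little. Within the data shown here, compound 1, the only measured compound with naphthalen-1-yl, gives a low number, but its core differs from that of compound 4, so it is only a rough guide. A downward step is expected, of moderate size, a number 9.8 percentage points lower from compound 3 to compound 4 (within the scatter), with wide uncertainty. Compound 4 is therefore estimated at 12%, in the range 2% to 28%.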

Compound 4, a percentage reported as inhibition, at one concentration (the size of the read-out at that concentration, not a potency): 5.98%
Compound 4: the middle estimate sits 6 percentage points above what was measured, within the range that was stated.
By their numbers in this assay, from the lowest: compounds 1, 2 and 4 (each within the scatter of the next); then compound 3.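

In this assay, on the benzyl-bearing core, this position next to the ring nitrogen proves sensitive to the choice of aryl group: naphthalen-1-yl in place of 4-ethylphenyl gives a number 15.8 percentage points lower from compound 3 to compound 4 (beyond the scatter). With naphthalen-1-yl held fixed, benzyl in place of cyclohexyl on the aromatic nitrogen gives a number 2.4 percentage points higher from compound 1 to compound 4 (within the scatter), so benzyl alone does not carry the higher number of compound 3. No evidence on hand bears on what lies behind the drop.

The compounds shown leave open whether 4-ethylphenyl would also lift the number on the cyclohexyl-bearing core, and whether a longer chain in place of ethyl, or an amine on that phenyl ring, would raise or lower it. From the compounds shown here alone, with one concentration and one cell line, potency and selectivity also remain open.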